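The source may hold more compounds than are shown below. What is called first, only, known or untested is meant among the compounds shown, and "the series" means these compounds.

Measured so far in a physicochemical assay for lipophilicity, at pH 7.4; a lower number here means a more polar compound, a higher number a more lipophilic compound:
compound 1 `Cc1cc(Nc2ccc(C(F)(F)F)cc2)n2nc(CCO)nc2n1`, 2.2
compound 2 `Cc1cc(Nc2ccc(S(F)(F)(F)(F)F)cc2)n2nc(C3CC3)nc2n1`, 3.5
compound 3 `Cc1cc(Nc2ccc(C(F)(F)F)cc2)n2nc(C3CC3)nc2n1`, 3.3

Compound 3 stands second highest of the three; in this assay compound 3 and compound 2 lie within the scatter of each other, while compound 1 sits clearly lower. Compound 4 `CCc1nc2nc(C)cc(Nc3ccc(C(F)(F)F)cc3)n2n1` differs from compound 3 in one place: ethyl in place of cyclopropyl on an aromatic carbon. Neither measured step matches this change. The step of a number 1.10 log units higher from compound 1 to compound 3 (beyond the scatter) removes a hydrogen-bond donor; the step of a number 0.20 log units lower from compound 2 to compound 3 (within the scatter) exchanges two fluorinated groups. Both only fix where compound 3 sits among its neighbours. Exchanging a small ring for an open chain is expected to give a small downward step; for compound 4 the expected step is a number 0.30 log units lower from compound 3 to compound 4 (within the scatter), at the edge of the scatter. Compound 4 is therefore estimated at 3 in this assay, in the range 2.6 to 3.4.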

Compound 4, distribution coefficient: 3
The estimate for compound 4 equals the measured number at the digits printed; the measured number falls inside the stated range.
By their numbers in this assay, from the lowest: compound 1; then compounds 4, 3 and 2 (each within the scatter of the next, the first and the last beyond it).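

In this assay, at the aromatic carbon between two ring nitrogen atoms, the step of a number 0.30 log units lower from compound 3 to compound 4 (within the scatter) shows that ethyl and cyclopropyl are not told apart here, so opening the three-membered ring at this place leaves the number within the scatter. With the chain kept and only the hydroxy gone, the step of a number 0.80 log units higher from compound 1 to compound 4 (beyond the scatter) lies beyond the scatter, a separation that compound 3, with its ring, could not isolate. From the compounds shown here alone, whether an amine, a carboxylic acid or a longer chain at this place would stay with ethyl and cyclopropyl remains open. No measurement at hand gives a reason for either step.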